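Fluoro in place of chloro on compound 3

This account rests on a few compounds, and the source may have more. Where it says the series, first, only, none or still open, it means among the compounds named here.

Values measured in a functional assay on KB-V1 cells (Homo sapiens) for cytotoxicity, read by MTT assay, with a stated time of 72 h (a higher number here means a weaker inhibitor, a lower number a stronger inhibitor), are these
Compound 1 `O=C1Nc2ccccc2/C1=N/NC(=S)NC1CCCCC1` gives 4380 nM
Compound 2 `O=C1Nc2ccccc2/C1=N/NC(=S)Nc1cccc(Cl)c1` gives 640 nM
Compound 3 `O=C1Nc2ccccc2/C1=N/NC(=S)Nc1ccc(Cl)cc1` gives 4990 nM

Compound 3 belongs to the upper pair of these three numbers. Its partner there, with cyclohexyl in place of 4-chlorophenyl, lies within the scatter (a 1.1-fold higher number from compound 1 to compound 3 (0.06 log units; within the scatter)) and the only clear separation is the modest one from the 3-chlorophenyl analogue (a 7.8-fold higher number from compound 2 to compound 3 (0.89 log units; beyond the scatter)) in this short series.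

The next compound, compound 4 `O=C1Nc2ccccc2/C1=N/NC(=S)Nc1ccc(F)cc1`, carries fluoro in place of chloro on an aromatic carbon, para to a large group (fluoro in place of chloro on an aromatic carbon) without any other alteration.

Going by the values given here, no measured step exchanges one halogen for another, so nothing bears on this change directly. The modest steps seen so far (a 6.8-fold lower number from compound 1 to compound 2 (0.84 log units; beyond the scatter) and a 7.8-fold higher number from compound 2 to compound 3 (0.89 log units; beyond the scatter)) both involve the 3-chlorophenyl compound, whereas the halogen of compound 4 keeps the place it has in compound 3. Compound 3 at 4990 nM is therefore the anchor, and no step beyond the scatter is expected in this assay for this exchange. The expected step is small (a 1.2-fold lower number from compound 3 to compound 4 (0.10 log units; within the scatter)) and remains uncertain. Compound 4 is estimated at 4000 nM with an expected range from 1500 nM to 10000 nM at this stage.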

Compound 4, half-maximal inhibitory concentration: 1920 nM
The estimate for compound 4 lay 2.1-fold (0.32 log units) above the measured number; low and high end bracket the measured number.
By their numbers in this assay, from the lowest: compound 2; then compound 4; then compounds 1 and 3 (each within the scatter of the next).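

In this assay, going by these compounds alone, the halogen at this place, para to a large group, proves able to move the number: the exchange gives a 2.6-fold lower number from compound 3 to compound 4 (0.41 log units; beyond the scatter) and is the first measured step between two halogens, modest in size but beyond the scatter. The same exchange also separates the 4-halophenyl series from the cyclohexyl compound, which compound 3 did not do, with a 2.3-fold lower number from compound 1 to compound 4 (0.36 log units; beyond the scatter) as the new gap, while compound 2 keeps the lowest number of the four, as a 3.0-fold higher number from compound 2 to compound 4 (0.48 log units; beyond the scatter) shows, so fluoro at this place narrows but does not close the distance to the 3-chlorophenyl compound. Nothing measured in this account explains the step from chloro to fluoro.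

The compounds shown leave open whether the same exchange of chloro for fluoro on compound 2 would give a step of like size and direction, so the two halogen effects cannot yet be set side by side. They also leave open how an unsubstituted phenyl, or bromo, methyl or methoxy on an aromatic carbon at this place, would compare with compound 3 and compound 4.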